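The source may hold more compounds than are shown below. What is called first, only, known or untested is meant among the compounds shown, and "the series" means these compounds.

Values in a physicochemical assay for lipophilicity, read by HPLC, using the shake flask method; on this read-out higher numbers stand for higher lipophilicity and lower numbers for lower lipophilicity:
- compound 1 `CCCCCN(Cc1ccc(Cl)nc1)/C(C)=N/C#N`: 2.37
- compound 2 `C/C(=N\C#N)N(Cc1ccccc1)Cc1ccc(Cl)nc1`: 2.11
- compound 3 `C=CCN(Cc1ccc(Cl)nc1)/C(C)=N/C#N`: 1.56

Among these three, compound 3 stands lowest at 1.56. The steps leading to it are a number 0.81 log units lower from compound 1 to compound 3 (beyond the scatter) and a number 0.55 log units lower from compound 2 to compound 3 (beyond the scatter). The remaining pair is close, with a number 0.26 log units lower from compound 1 to compound 2 (within the scatter).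

The next compound is compound 4 `CCN(Cc1ccc(Cl)nc1)/C(C)=N/C#N`, not yet measured in this assay. Its change is methyl in place of vinyl on a saturated chain carbon bound to an amine nitrogen, which also reads as allyl to ethyl.

For the measured compounds named here, no measured step makes this exact change, so the evidence is indirect. The two steps that bear on it are those ending in vinyl, a number 0.81 log units lower from compound 1 to compound 3 (beyond the scatter) and a number 0.55 log units lower from compound 2 to compound 3 (beyond the scatter). Both swap a different group at the same place and both go downward. Going by the values given here, only three compounds support this direction, and the change to methyl is smaller than either swap. A small downward move is therefore expected, probably not clearly beyond the scatter and smaller than a number 0.55 log units lower from compound 2 to compound 3 (beyond the scatter).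

The estimated step is a number 0.26 log units lower from compound 3 to compound 4 (within the scatter).

For compound 4 the expected value is 1.3, with an estimated range from 0.95 to 1.65.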

Compound 4, partition coefficient: 1.19
The estimate for compound 4 lay 0.11 log units above the measured number, within the range that was stated.
By their numbers in this assay, from the lowest: compound 4; then compound 3; then compounds 2 and 1 (each within the scatter of the next).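

For the compounds shown here, replacing vinyl with methyl on a saturated chain carbon bound to an amine nitrogen, also readable as allyl to ethyl, gives the first direct reading of this change in this assay (a number 0.37 log units lower from compound 3 to compound 4 (beyond the scatter)), and the move is beyond the scatter. The ethyl compound also widens the span at this place, with the steps from the phenyl and butyl compounds (a number 0.92 log units lower from compound 2 to compound 4 (beyond the scatter); a number 1.18 log units lower from compound 1 to compound 4 (beyond the scatter)) both exceeding any step among the first three compounds, and the second also readable as hydrogen in place of propyl on a saturated chain carbon, two bonds along the chain from an amine nitrogen. Across these four compounds, the methyl and vinyl compounds sit lowest and the phenyl and butyl compounds sit above them with no order between those two, while nothing here accounts for the size of any of these steps.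

On these data alone, whether the downward trend continues with a shorter group, such as a bare hydrogen on the amine nitrogen, stays open. Also open, as far as these compounds go, is how a hydroxyl, an amine or a carboxylic acid on the chain at this place would read against the ethyl compound.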